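Swapping Methoxy for Chloro on Compound 1

The source may report more compounds than this note shows. Statements on the series, on what has been measured and on what is new or still open speak of the compounds shown alone.

In a functional assay on NSCLC cells (Homo sapiens) for cytotoxicity, with a stated time of 48 h (a higher number here means a weaker inhibitor of growth, a lower number a stronger inhibitor of growth), compound 1 (`COc1ccc(CN2C(=O)/C(=C\c3cc(OC)c(OC)c(OC)c3)c3ccccc32)cc1`) gives 2000 nM. Among the compounds with values here, the only other measured compound, compound 2 (`COc1cc(/C=C2/C(=O)N(C)c3ccc(O)cc32)cc(OC)c1OC`), gives 6300 nM. Compound 1 therefore has the lower of the two numbers and is the stronger inhibitor of growth so far, by a margin beyond the usual scatter of repeated measurements.

Compound 3 (`COc1cc(/C=C2\C(=O)N(Cc3ccc(Cl)cc3)c3ccccc32)cc(OC)c1OC`) keeps the core of compound 1 and changes one group: 4-methoxybenzyl becomes 4-chlorobenzyl, with chloro in place of methoxy on an aromatic carbon. Within the data shown here, no two measured compounds differ in only one place, so the data offer no direct guide to the effect of this swap. The expected result is a 1.3-fold lower number from compound 1 to compound 3 (0.10 log units; within the scatter), which would be no real change beyond the scatter. For compound 3 the estimated value is 1600 nM, with an expected range of 500 nM to 5000 nM.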

Compound 3, concentration for 50% growth inhibition: 3400 nM
For compound 3 the middle estimate is 2.1-fold (0.33 log units) below the measured one; the range from low to high includes it.
By their numbers in this assay, from the lowest: compounds 1, 3 and 2 (each within the scatter of the next, the first and the last beyond it).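

Within the data shown here, compound 3 gives the first direct reading at this position: in this assay the swap on the benzyl group gives a 1.7-fold higher number from compound 1 to compound 3 (0.23 log units; within the scatter) for chloro in place of methoxy. On the core of compound 1, then, a methoxy with its hydrogen-bond acceptor can give way to a single chlorine with no change that stands clear of repeat measurements. This holds for this one pair only, and nothing shown here offers a measured explanation for the result.

From the compounds shown here alone, whether the same position would accept an amine, a carboxylic acid or a longer chain remains open. Also open, going by these compounds, is whether swapping methoxy for chloro would give a similar result on a different core, or at another place on the aromatic ring.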